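Hydrazide-to-amide swap on a thiophene urea series

This account rests on a few compounds, and the source may have more. Where it says the series, first, only, none or still open, it means among the compounds named here.

Measured so far:
compound 1 `O=C(Nc1sc2c(c1C(=O)NNc1ccccc1)CCCCC2)NS(=O)(=O)c1ccccc1` — 16000 nM
compound 2 `O=C(Nc1sc2c(c1C(=O)NNc1ccc(Cl)cc1)CCCCC2)NS(=O)(=O)c1ccccc1` — 8600 nM

Compound 1 gives the higher of the two numbers in a functional assay on NSCLC cells (Homo sapiens) for inhibition, with a stated time of 48 h; a higher number here means a weaker inhibitor of growth, a lower number a stronger inhibitor of growth; its nearest neighbour is compound 2, with a 1.9-fold lower number from compound 1 to compound 2 (0.27 log units; within the scatter). Compound 3 `CCCNC(=O)c1c(NC(=O)NS(=O)(=O)c2ccccc2)sc2c1CCCCC2` has not been tested. It differs from compound 1 by propyl in place of anilino on an amide-type nitrogen. No measured step touches this nitrogen, so nothing shown bears on it directly, and the single recorded step leaves the shared core barely moved. Compound 3 is therefore expected to give a 1.3-fold higher number from compound 1 to compound 3 (0.10 log units; within the scatter), with no change beyond the scatter assumed. The estimate for compound 3 is 20000 nM, within 6000 nM to 60000 nM.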

Compound 3, concentration for 50% growth inhibition: 54200 nM
The estimate for compound 3 lay 2.7-fold (0.43 log units) below the measured number; low and high end bracket the measured number.
By their numbers in this assay, from the lowest: compounds 2 and 1 (each within the scatter of the next); then compound 3.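

In this assay propyl in place of anilino gives a 3.4-fold higher number from compound 1 to compound 3 (0.53 log units; beyond the scatter) and propyl in place of (4-chlorophenyl)amino gives a 6.3-fold higher number from compound 2 to compound 3 (0.80 log units; beyond the scatter) on the same amide-type nitrogen. This nitrogen is therefore the first place in the series where a change moves the number beyond the scatter, and both steps run towards a weaker inhibitor of growth. No measurement shown accounts for this loss.

The swap removes the aromatic ring and the anilino nitrogen together, so their separate contributions stay unresolved. As far as these compounds go, whether benzylamino, a longer chain such as hexyl, or a terminal carboxylic acid on the propyl chain would recover the number remains open.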